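A Shorter Chain on the Oxygen: Estimate for Compound 3

This account rests on a few compounds, and the source may have more. Where it says the series, first, only, none or still open, it means among the compounds named here.

Two measured compounds share one core and differ only in the chain hanging from the oxygen next to a carbonyl group. Compound 1 `C=CCOC(=O)Nc1ccc([Se]C#N)cc1` carries a short chain ending in vinyl, and in a functional assay on PC-3 cells (Homo sapiens) for cytotoxicity, read by MTT assay, with a stated time of 72 h (on this read-out lower numbers stand for stronger inhibition of growth and higher numbers for weaker inhibition of growth), compound 1 gives 17600 nM. Compound 2 `CCCCCCOC(=O)Nc1ccc([Se]C#N)cc1` carries a longer chain, and in this assay compound 2 gives 17300 nM. The step of a 1.0-fold lower number from compound 1 to compound 2 (0.01 log units; within the scatter) shows that lengthening the chain left the number essentially unchanged, so compound 2 stands within the scatter of compound 1 and neither can be called stronger.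

Compound 3 `CCOC(=O)Nc1ccc([Se]C#N)cc1` has not yet been measured. It differs from compound 2 by hydrogen in place of butyl on a saturated chain carbon, two bonds along the chain from an oxygen next to a carbonyl group, which cuts the chain back to ethyl. Going by the values given here, the only measured step that bears on this change is the one between compound 1 and compound 2, and it stayed within the scatter despite a sizeable change in chain length. On the strength of a 1.0-fold lower number from compound 1 to compound 2 (0.01 log units; within the scatter), the expected step of a 1.0-fold lower number from compound 2 to compound 3 (0.01 log units; within the scatter) in this assay is none beyond the scatter. Compound 3 is therefore estimated to give about 17000 nM in this assay, within a range from 7000 nM to 40000 nM.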

Compound 3, concentration for 50% growth inhibition: 9900 nM
Estimate against measurement, compound 3: 1.7-fold (0.23 log units) above; the range from low to high includes it.
By their numbers in this assay, from the lowest: compounds 3, 2 and 1 (each within the scatter of the next).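

Cutting the chain from hexyl back to ethyl gives, in this assay, a 1.7-fold lower number from compound 2 to compound 3 (0.24 log units; within the scatter) and so even removing butyl from this place on the chain produces no change that can be told apart from repeat-to-repeat variation. Putting methyl in place of vinyl on the short chain gives a 1.8-fold lower number from compound 1 to compound 3 (0.25 log units; within the scatter) and this shows that the vinyl end is not needed to keep the number in this range, since the three chains shown, ending in vinyl, in methyl or in butyl, all stand within the scatter of one another and no order among them can be read. Nothing shown here offers an explanation for how little these chains separate from one another.

As far as these compounds go, what remains open is whether a chain of a different kind at this place, such as one carrying an amine or a carboxylic acid, or one ending in a phenyl ring, would move the number beyond the scatter. A longer chain than hexyl, or a branched one such as tert-butyl, also remains untested among the compounds shown here, so the flat picture holds only for these three chains.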